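The source may hold more compounds than are shown below. What is called first, only, known or untested is meant among the compounds shown, and "the series" means these compounds.

Measured compounds:
compound 1 `NC(=O)c1c(NC(=O)c2ccccc2Cl)sc2c1CCN(Cc1ccc(Cl)cc1)C2` — 22500 nM
compound 2 `NC(=O)c1c(NC(=O)c2ccccc2Cl)sc2c1CCN(Cc1c(Cl)cccc1Cl)C2` — 4850 nM
compound 3 `NC(=O)c1c(NC(=O)c2ccccc2Cl)sc2c1CCN(C(=S)Nc1ccccc1F)C2` — 4970 nM

In a functional assay on HL-60 cells (Homo sapiens) for antiproliferative activity, with a stated time of 24 h (a higher number here means a weaker inhibitor, a lower number a stronger inhibitor), compound 3 stands second highest of the three numbers. Compound 2 sits nearest to it, and the pair lie within the scatter of one another, as the step of a 1.0-fold higher number from compound 2 to compound 3 (0.01 log units; within the scatter) shows. Compound 1 is the furthest off; the step of a 4.5-fold lower number from compound 1 to compound 3 (0.66 log units; beyond the scatter) is beyond the scatter, as is the step of a 4.6-fold lower number from compound 1 to compound 2 (0.67 log units; beyond the scatter).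

Compound 4 `CSc1ccccc1NC(=S)N1CCc2c(sc(NC(=O)c3ccccc3Cl)c2C(N)=O)C1` differs from compound 3 only at the thiourea-borne ring: methylsulfanyl in place of fluoro on an aromatic carbon. Neither of the measured steps bears directly on this change, since both of them alter the whole group on the amine nitrogen in the ring rather than a substituent on the six-membered aromatic ring of the thiourea. The data therefore give no grounds to expect a step beyond the scatter in this assay in either direction. Compound 4 is estimated at 4500 nM, with a range from 1500 nM to 13500 nM, which amounts to an expected step of a 1.1-fold lower number from compound 3 to compound 4 (0.04 log units; within the scatter).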

Compound 4, half-maximal inhibitory concentration: 14600 nM
Compound 4: the middle estimate sits 3.2-fold (0.51 log units) below what was measured; measured number outside the range, above it.
By their numbers in this assay, from the lowest: compounds 2 and 3 (each within the scatter of the next); then compounds 4 and 1 (each within the scatter of the next).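

In this assay, among these compounds, the substituent on this aromatic carbon proves able to move the result: methylsulfanyl in place of fluoro gives the first measured change confined to this position (a 2.9-fold higher number from compound 3 to compound 4 (0.47 log units; beyond the scatter)). Compound 3 had matched the 2,6-dichlorophenyl compound, but the 2-(methylsulfanyl)phenyl thiourea does not (a 3.0-fold higher number from compound 2 to compound 4 (0.48 log units; beyond the scatter)), and it instead lies within the scatter of the 4-chlorophenyl compound (a 1.5-fold lower number from compound 1 to compound 4 (0.19 log units; within the scatter)). Nothing among the data shown accounts for this shift.

The compounds shown leave open whether a methoxy group or an amine on the same aromatic carbon would read like fluoro or like methylsulfanyl. They also leave open how a plain phenyl on the thiourea, with no substituent at all, would compare with compound 3 and compound 4.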